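This account rests on a few compounds, and the source may have more. Where it says the series, first, only, none or still open, it means among the compounds named here.

Two compounds built on one shared core have been examined in an assay on CHO cells for displacement of a labelled ligand from adenosine receptor A1 (Homo sapiens), read by scintillation counting, with a stated time of 60 min, tested at 10 uM; on this read-out higher numbers stand for more inhibition at the one concentration tested (going by the name of the read-out) and lower numbers for less inhibition. Compound 1 `CNC(=O)[C@@]12C[C@@H]1[C@@H](n1cnc3c(NC)nc(C#Cc4ccc(F)cc4)nc31)[C@H](O)[C@@H]2O` gives 27%. Compound 2 `CNC(=O)[C@@]12C[C@@H]1[C@@H](n1cnc3c(NC)nc(C#Cc4ccsc4)nc31)[C@H](O)[C@@H]2O` gives 11%, the lower of the two numbers. Among the measured compounds shown here, the single measured step, a number 16 percentage points lower from compound 1 to compound 2 (beyond the scatter), swapped one aromatic ring for another on a triple-bonded carbon. Compound 3 `CNC(=O)[C@@]12C[C@@H]1[C@@H](n1cnc3c(NC)nc(C#CC4CCCCC4)nc31)[C@H](O)[C@@H]2O` differs from compound 2 by cyclohexyl in place of thiophen-3-yl on a triple-bonded carbon. For the measured compounds named here, no measured step covers such an exchange: the one step that exists moves between two aromatic rings, whereas here a six-membered non-aromatic ring of carbon only replaces the five-membered aromatic ring, so that step gives only weak guidance. With compound 2 already near the bottom of the scale, little room remains downward, and nothing in these data points to a large rise. Compound 3 is therefore expected to land at 15%, within 0% to 40%. The step of a number 4 percentage points higher from compound 2 to compound 3 (within the scatter) is expected to stay within the scatter.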

Compound 3, a percentage reported as inhibition, at one concentration (the size of the read-out at that concentration, not a potency): 15%
Estimate against measurement, compound 3: no gap at the digits printed, and the stated range covers the measured number.
By their numbers in this assay, from the lowest: compounds 2 and 3 (each within the scatter of the next); then compound 1.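

Until now only aromatic rings had been seen on this triple-bonded carbon. Compound 3 shows that cyclohexyl, a non-aromatic ring of carbon only, can take that place, and this assay does not separate it from thiophen-3-yl (a number 4 percentage points higher from compound 2 to compound 3 (within the scatter)). The 4-fluorophenyl group still reads highest of the three (a number 12 percentage points lower from compound 1 to compound 3 (beyond the scatter)), but no measurement here explains why.

Still open, as far as these compounds go, is whether the fluorine of compound 1 contributes to its higher number, which a plain phenyl ring on the same carbon would help to test. Also open, from the compounds shown here alone, is how an open-chain group, such as a longer alkyl chain, or a ring carrying an amine or a carboxylic acid, would read at this position.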